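This account rests on a few compounds, and the source may have more. Where it says the series, first, only, none or still open, it means among the compounds named here.

Compound 1, `Fc1cccc(-c2nc(Nc3ccccc3)c3ccccc3n2)c1`, tested in a functional assay on U-937 cells (Homo sapiens) for cytotoxicity, read by MTT assay, with a stated time of 48 h; a higher number here means a weaker inhibitor, a lower number a stronger inhibitor: the value for compound 1 is a limit of the assay, > 50000 nM.
Compound 2, `Fc1ccc2nc(-c3ccccc3)nc(Nc3ccccc3)c2c1`: the value for compound 2 in this assay is likewise a limit, > 50000 nM.
Compound 3, `Fc1cccc(-c2nc(Nc3ccccc3Cl)c3cc(F)ccc3n2)c1`: the value for compound 3 in this assay is again a limit, > 50000 nM.

Compound 3 stands where every measured member of the series stands, at the limit of > 50000 nM in this assay, at which 3 of the 3 values shown sit. Within the data shown here, no compound in the set gives a number, so there is no measured step to compare against, and no ranking among compounds 1, 2 and 3 can be drawn from these readings.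

Compound 4, `Nc1ccccc1Nc1nc(-c2cccc(F)c2)nc2ccc(F)cc12`, has not yet been measured in this assay. It differs from compound 3 by amino in place of chloro on an aromatic carbon. Among the measured compounds shown here, with no measured step to lean on, the expectation for compound 4 rests only on the fact that compound 3 sits at the limit; the expected step that the limit leaves unreadable from compound 3 to compound 4 is therefore taken as none beyond the scatter, and the likeliest outcome is that compound 4 also returns only a limit. The estimate for compound 4 in this assay is 60000 nM, with a range of 20000 nM to 200000 nM.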

Compound 4, half-maximal inhibitory concentration: 47300 nM
Compound 4: middle estimate off by 1.3-fold (0.10 log units), on the high side; low and high end bracket the measured number.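

In this assay, among these compounds, compound 4 is the first member of the series to return a number, 47300 nM, so the 2-aminophenyl group gives a readable value. At the same position the 2-chlorophenyl group gave only a limit. Amino in place of chloro on an aromatic carbon, ortho to a large group, gives an at least 1.0-fold lower number from compound 3 to compound 4 (0.02 log units; that floor lies within the scatter); this is only a floor, so the true size of the step remains unknown and no real shift can be claimed from it. The other readings offer no number to set compound 4 against: the limit of > 50000 nM in this assay, at which 3 of the 4 values shown sit.

Open, from the compounds shown here alone, is whether a hydroxyl, a methoxy or an acetylated amine on the same aromatic carbon would also give a number, and where it would fall. Also open, going by these compounds, is whether the 2-aminophenyl group would give a number on the core of compound 1.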